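The source may hold more compounds than are shown below. What is called first, only, known or untested is meant among the compounds shown, and "the series" means these compounds.

In a functional assay (plasma) for inhibition, with Canis familiaris (Canis lupus familiaris) as the target (on this read-out lower numbers stand for stronger inhibition and higher numbers for weaker inhibition), compound 1 `CC(=O)N[C@H]1CSSC(C)(C)[C@H](C(N)=O)NC(=O)[C@H](CC(=O)O)NC(=O)CNC(=O)[C@H](CCCN=C(N)N)N(C)C1=O` gives 360 nM and compound 2 `CCCCC(=O)N[C@H]1CSSC(C)(C)[C@H](C(N)=O)NC(=O)[C@H](CC(=O)O)NC(=O)CNC(=O)[C@H](CCCN=C(N)N)N(C)C1=O` gives 250 nM. These two numbers lie within the usual scatter of each other, so compound 2 stands level with compound 1 on the data so far. The next compound to consider is compound 3 `CN1C(=O)[C@@H](N)CSSC(C)(C)[C@H](C(N)=O)NC(=O)[C@H](CC(=O)O)NC(=O)CNC(=O)[C@@H]1CCCN=C(N)N`, which differs from compound 2 in one place: hydrogen in place of butylcarbonyl on an amine nitrogen. In words, this is hydrogen in place of butylcarbonyl on an amine nitrogen, so that (butylcarbonyl)amino becomes amino.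

Going by the values given here, only one measured step bears on this change. a 1.4-fold lower number from compound 1 to compound 2 (0.16 log units; within the scatter) came from propyl in place of hydrogen on a saturated chain carbon bound to a carbonyl carbon. That step altered only the chain on the carbonyl, and it stayed small. Among the compounds with values here, no compound here shows what happens when the carbonyl leaves as well, so this evidence is indirect. In this assay, no clear step beyond the scatter is therefore expected, with a slight lean towards a higher number. The expected change is a 1.6-fold higher number from compound 2 to compound 3 (0.20 log units; within the scatter). For compound 3 the estimate is 400 nM, with an expected range from 130 nM to 1200 nM.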

Compound 3, half-maximal inhibitory concentration: 200 nM
Beside the measured number, compound 3's estimate is 2.0-fold (0.30 log units) above it; the measured number falls inside the stated range.
By their numbers in this assay, from the lowest: compounds 3, 2 and 1 (each within the scatter of the next).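

Up to now only the chain on the carbonyl had changed; compound 3 loses the carbonyl as well, leaving a bare amino group on the saturated ring carbon, and this assay shows a 1.3-fold lower number from compound 2 to compound 3 (0.10 log units; within the scatter) for that change. Replacing acetyl in the same place gives a 1.8-fold lower number from compound 1 to compound 3 (0.26 log units; within the scatter) and so also stays inside the scatter, which means that, among these compounds, neither butylcarbonyl nor acetyl on this amine nitrogen is needed to keep the number in this range. The data available here offer no explanation for how closely the three compounds agree.

From the compounds shown here alone, whether a much longer chain, a benzoyl group or a chain ending in a carboxylic acid on this nitrogen would move the number beyond the scatter remains open. Going by these compounds, it is also open whether the nitrogen itself matters, a question that a hydroxyl group or a plain hydrogen in place of the whole amino group would address.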